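The compounds below may be only part of what the source reports. "The series", "measured", "known", "first", "only" and "open" are said of these compounds alone.

Compound 3 `COc1ccc(N/C=C\C(=O)c2cn(-c3ccccc3)nc2-c2ccc(F)cc2)cc1` gives 4600 nM in a functional assay on PC-3 cells (Homo sapiens) for antiproliferative activity, read by MTT assay, with a stated time of 48 h (on this read-out higher numbers stand for weaker inhibition and lower numbers for stronger inhibition), the highest of the three numbers shown, by margins that stay within the scatter. Compound 1 `O=C(/C=C\Nc1ccc(Cl)cc1)c1cn(-c2ccccc2)nc1-c1ccc(F)cc1` gives 3800 nM and compound 2 `O=C(/C=C\Nc1ccc(O)cc1)c1cn(-c2ccccc2)nc1-c1ccc(F)cc1` gives 2600 nM; the steps of a 1.2-fold higher number from compound 1 to compound 3 (0.08 log units; within the scatter) and a 1.8-fold higher number from compound 2 to compound 3 (0.25 log units; within the scatter) both lie within the scatter, as does a 1.5-fold lower number from compound 1 to compound 2 (0.16 log units; within the scatter). Compound 4 `COc1ccc(N/C=C\C(=O)c2cn(-c3ccccc3)nc2-c2ccc(Cl)cc2)cc1` differs from compound 3 by chloro in place of fluoro on an aromatic carbon. For the measured compounds named here, none of the measured steps touches that ring; all three concern the aromatic ring on the nitrogen, and each stays within the scatter. No direction can be drawn from them, so the expected step of a 1.1-fold lower number from compound 3 to compound 4 (0.04 log units; within the scatter) in this assay is none beyond the scatter. Compound 4 is therefore estimated at 4200 nM, with a range of 1800 nM to 9500 nM.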

Compound 4, half-maximal inhibitory concentration: 10700 nM
Estimate against measurement, compound 4: 2.5-fold (0.41 log units) below; measured number outside the range, above it.
By their numbers in this assay, from the lowest: compounds 2, 1 and 3 (each within the scatter of the next); then compound 4.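

The 4-fluorophenyl to 4-chlorophenyl change gives a 2.3-fold higher number from compound 3 to compound 4 (0.37 log units; beyond the scatter), the only step shown that lies beyond the scatter. The group on this ring therefore affects the read-out, whereas the changes among compounds 1, 2 and 3 on the other aromatic ring stayed within the scatter. Nothing available gives a reason for this step.

Going by these compounds, what bromo, methyl or an amine would give at this place stays open. So does whether the same change gives a similar step with the chloro of compound 1 or the hydroxy of compound 2 in place of the methoxy.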